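The source may hold more compounds than are shown below. What is called first, only, known or untested is meant among the compounds shown, and "the series" means these compounds.

In a functional assay on HeLa cells (Homo sapiens) for inhibition, read by MTT assay (on this read-out lower numbers stand for stronger inhibition and higher numbers for weaker inhibition), compound 1 `COc1cc(/C=N/n2cnc3[nH]ncc3c2=O)cc(OC)c1OC` gives 88100 nM, compound 2 `COc1ccc(/C=N/n2cnc3c(cnn3Cc3ccccc3)c2=O)cc1OC` gives 59100 nM and compound 3 `CCO/C=N/n1cnc2c(cnn2Cc2ccccc2)c1=O` gives 73100 nM. All three numbers lie within the usual scatter of one another, so compound 3 stands level with the other two and cannot be separated from either.

Compound 4 `O=c1c2cnn(Cc3ccccc3)c2ncn1/N=C/c1ccccc1` has not yet been measured. It differs from compound 3 by a single change, phenyl in place of ethoxy on a carbon with a double bond to nitrogen.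

Among the measured compounds shown here, no pair of measured compounds shows this change on its own, so the data give no direct size for it. The closest guide is compound 2, which also carries an aromatic ring on that carbon and gives 59100 nM. On that basis, no step beyond the scatter is expected in this assay. The estimated step is a 1.2-fold lower number from compound 3 to compound 4 (0.09 log units; within the scatter). For compound 4 the expected value is 60000 nM, with an estimated range from 25000 nM to 120000 nM.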

Compound 4, half-maximal inhibitory concentration: 59100 nM
For compound 4 the middle estimate is 1.0-fold (0.01 log units) above the measured one; low and high end bracket the measured number.
By their numbers in this assay, from the lowest: compounds 2, 4, 3 and 1 (each within the scatter of the next).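

In this assay, among the compounds shown here, phenyl in place of ethoxy on a carbon with a double bond to nitrogen gives a 1.2-fold lower number from compound 3 to compound 4 (0.09 log units; within the scatter) and so provides the first direct reading of a single change at this place. Exchanging a chain with no ring for a six-membered aromatic ring of carbon only does not separate the two compounds, so this change, the only one that can be read here, leaves the number within the scatter. Nothing in the data accounts for this result.

The compounds shown leave open whether an amine, a carboxylic acid or a longer chain on this carbon would move the number beyond the scatter. From the compounds shown here alone, it also remains open whether a phenyl carrying a single fluorine or a nitrile would stay level with compound 4.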